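From pentyl to benzyl at the assay limit

The source may hold more compounds than are shown below. What is called first, only, known or untested is meant among the compounds shown, and "the series" means these compounds.

Values in a functional assay on HOS cells (Homo sapiens) for antiproliferative activity, read by sulforhodamine B assay (on this read-out higher numbers stand for weaker inhibition of growth and lower numbers for stronger inhibition of growth), for the three measured compounds

- compound 1 `C[C@@H]1O[C@H](COCc2ccccc2)[C@@H](OCc2ccccc2)[C@H](OCc2ccccc2)C1=O` gives > 50000 nM as a limit
- compound 2 `CCC[C@@H]1O[C@H](COCc2ccccc2)[C@@H](OCc2ccccc2)[C@H](OCc2ccccc2)C1=O` gives > 50000 nM as a limit
- compound 3 `CCCCC[C@@H]1O[C@H](COCc2ccccc2)[C@@H](OCc2ccccc2)[C@H](OCc2ccccc2)C1=O` gives > 50000 nM as a limit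

In this assay compound 3 gives > 50000 nM and this is a limit, not a number. For the measured compounds named here, the whole series so far comes down to the limit of > 50000 nM in this assay, at which 3 of the 3 values shown sit, and no compound has yet given a number to compare.

Compound 4 `O=C1[C@H](Cc2ccccc2)O[C@H](COCc2ccccc2)[C@@H](OCc2ccccc2)[C@@H]1OCc1ccccc1` has not been measured. Its difference from compound 3 is phenyl in place of butyl on a saturated chain carbon bound to a saturated ring carbon and the same difference, cut one bond further out, reads pentyl to benzyl.

Going by the values given here, three measured steps bear on this change. They are a step that the two limits leave unreadable from compound 1 to compound 2 and a step that the two limits leave unreadable from compound 1 to compound 3 and a step that the two limits leave unreadable from compound 2 to compound 3 and none of them has a size that can be read. None of them brings in a phenyl, so they give only a weak guide.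

The expectation in this assay is therefore no clear change in either direction. The estimated step is a number no higher from compound 3 to compound 4 (the limit leaves the size open) and no more than that is expected. For compound 4 the estimated value is 50000 nM with an expected range of 20000 nM to 100000 nM and a further limit is the likeliest report.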

Compound 4, concentration for 50% growth inhibition: > 50000 nM
Compound 4 gave a limit, no number; the forecaster's own chance of this, stated with the estimate: 85%; the middle value lies on the limit itself.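

In this assay compound 4 gives > 50000 nM, a limit and not a number. No step can be read among compound 1, compound 2, compound 3 and compound 4, which all stand at one limit: the limit of > 50000 nM in this assay, at which 4 of the 4 values shown sit.

The compounds shown leave open whether hydrogen, ethyl, butyl or phenyl at this place makes any difference to growth inhibition.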